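This account rests on a few compounds, and the source may have more. Where it says the series, first, only, none or still open, it means among the compounds named here.

Measured so far in an ADME assay on WI-38 cells (Homo sapiens) for inhibition, read by CellTiter-Glo, with a stated time of 48 h, tested at 100 uM; a lower number here means less inhibition, a higher number more inhibition at the concentration tested (going by the name of the read-out):

- compound 1, `CCOC(=O)/C=C\NC(=O)[C@H](O)C(C)(C)CO`, gives 1%
- compound 2, `CC(C)(C)OC(=O)/C=C/NC(=O)[C@H](O)C(C)(C)CO`, gives 0%
- compound 3, `CC(C)(C)OC(=O)/C=C\NC(=O)[C@@H](O)C(C)(C)CO`, gives 26%

Compound 3 stands highest of these three numbers, beyond the scatter above both others. Among the compounds with values here, the only measured step that changes a single thing is a number 26 percentage points higher from compound 2 to compound 3 (beyond the scatter); that step rests on (the fact that compounds 2 and 3 differ only in the configuration as drawn), so it tells nothing about the ester group. Compound 1, which like compound 3 has a Z double bond but carries an ethyl ester and the other drawn configuration at the hydroxyl-bearing carbon, sits far below compound 3.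

Compound 4, `COC(=O)/C=C\NC(=O)[C@@H](O)C(C)(C)CO`, keeps the configuration of compound 3 and differs from it by methyl in place of tert-butyl on an oxygen next to a carbonyl group. Within the data shown here, no measured step bears on such an ester change, so the direction is open. Among the measured compounds shown here, since the single high number belongs to compound 3 and every other compound sits near zero, a downward step toward those values is expected, a number 14 percentage points lower from compound 3 to compound 4 (beyond the scatter). Compound 4 is therefore estimated at 12%, with a range from 0% to 35%.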

Compound 4, a percentage reported as inhibition, at one concentration (the size of the read-out at that concentration, not a potency): -20%
Compound 4: middle estimate off by 32 percentage points, on the high side; the measured number lies below the stated range.
By their numbers in this assay, from the lowest: compound 4; then compounds 2 and 1 (each within the scatter of the next); then compound 3.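

In this assay, the ester group proves to matter: with the double bond and the drawn configuration held as in compound 3, methyl in place of tert-butyl on an oxygen next to a carbonyl group gives a number 46 percentage points lower from compound 3 to compound 4 (beyond the scatter), a large change. Within the data shown here, this is the first measured step at this position, and the number for compound 4, -20%, lies below zero rather than simply shrinking toward it. Nothing at hand explains why the tert-butoxy to methoxy change has this effect.

Among these compounds, only one single-place step speaks for this position, so it remains unknown whether a similar step would appear with the other drawn configuration or the E double bond. On these data alone, what an isopropyl ester, a longer chain or a free carboxylic acid would give at this place also stays open.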